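The source may hold more compounds than are shown below. What is called first, only, known or untested is meant among the compounds shown, and "the series" means these compounds.

Measured compounds:
compound 1 `CCCC(=O)N1N=C(c2cc(OC)ccc2N)SC1(C)C` — 91.1%
compound 2 `COc1ccc(N)c(C2=NN(C(=O)C3CCC3)C(C)(C)S2)c1` — 57.8%
compound 3 `CCCC(=O)N1N=C(c2cc(Cl)ccc2N)SC1(C)C` — 66.2%

These three were tested in an assay on isolated protein for inhibition of Nitric oxide synthase, inducible (Homo sapiens), read by scintillation counting, with a stated time of 30 min, tested at 50 uM; a higher number here means more inhibition at the concentration tested (going by the name of the read-out), a lower number less inhibition. Compound 3 stands second highest of the three; its nearest neighbour is compound 2, within the scatter, while compound 1 lies clearly above it, a number 24.9 percentage points lower from compound 1 to compound 3 (beyond the scatter). Compound 4 `CC1(C)SC(c2cc(Cl)ccc2N)=NN1C(=O)C1CCC1` is not yet measured. It differs from compound 3 by cyclobutyl in place of propyl on a carbonyl carbon. For the measured compounds named here, the only step that bears on this change is the one from compound 1 to compound 2, the same exchange on a different aromatic substituent, which gave a number 33.3 percentage points lower from compound 1 to compound 2 (beyond the scatter). A drop of similar kind is therefore expected, a number 28.2 percentage points lower from compound 3 to compound 4 (beyond the scatter), though compound 3 starts from a lower number than compound 1. Compound 4 is estimated at 38%, between 15% and 60%.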

Compound 4, a percentage reported as inhibition, at one concentration (the size of the read-out at that concentration, not a potency): -4.65%
For compound 4 the middle estimate is 42.7 percentage points above the measured one; the measured number lies below the stated range.
By their numbers in this assay, from the lowest: compound 4; then compounds 2 and 3 (each within the scatter of the next); then compound 1.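

In this assay, cyclobutyl in place of propyl on a carbonyl carbon gives a number 70.9 percentage points lower from compound 3 to compound 4 (beyond the scatter), and chloro in place of methoxy on an aromatic carbon gives a number 62.5 percentage points lower from compound 2 to compound 4 (beyond the scatter). The two changes do not act independently, as the cyclobutyl exchange costs more with chloro than with methoxy: the same change on two cores in this assay, a number 33.3 percentage points lower (beyond the scatter) from compound 1 to compound 2 and a number 70.9 percentage points lower (beyond the scatter) from compound 3 to compound 4, 37.6 percentage points apart, beyond the scatter of two such steps. Likewise, the chloro exchange costs more with cyclobutyl than with propyl: the same change on two cores in this assay, a number 24.9 percentage points lower (beyond the scatter) from compound 1 to compound 3 and a number 62.5 percentage points lower (beyond the scatter) from compound 2 to compound 4, 37.6 percentage points apart, beyond the scatter of two such steps. On these data alone, whether cyclopropyl or a longer chain on the carbonyl carbon would lose as much with chloro stays open. So does whether fluoro on the aromatic carbon would behave like chloro or like methoxy.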